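A few compounds are considered here, and "the series" means these few. Any claim that something is new, unique, unknown or untested is made for them only; others in the source may bear on it.

Working notes on the series, read in an ADME assay on Vero cells (Chlorocebus sabaeus) for cytotoxicity, read by resazurin assay, with a stated time of 72 h; a lower number here means a stronger inhibitor, a higher number a weaker inhibitor. Compound 1 (`O=C(CCN1CCN(c2ccc([N+](=O)[O-])cc2)CC1)c1ccc(Br)cc1`) gives 79800 nM, compound 2 (`O=C(CCN1CCN(c2ccc(C(F)(F)F)cc2)CC1)c1ccc(F)c(F)c1`) gives 14000 nM, and compound 3 (`O=C(CCN1CCN(c2ccc([N+](=O)[O-])cc2)CC1)c1ccc(F)c(F)c1`) gives 122000 nM. Compound 3 therefore stands level with compound 1 at the high end of these numbers, with compound 2 clearly lower. The 3,4-difluorophenyl in place of 4-bromophenyl accounts for a 1.5-fold higher number from compound 1 to compound 3 (0.18 log units; within the scatter), while nitro in place of trifluoromethyl accounts for an 8.7-fold higher number from compound 2 to compound 3 (0.94 log units; beyond the scatter).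

Next is compound 4 (`O=C(CCN1CCN(c2ccc([N+](=O)[O-])cc2)CC1)c1ccc(Cl)c(F)c1`), which has chloro in place of fluoro on an aromatic carbon, ortho to a fluoro group and para to a large group, turning 3,4-difluorophenyl into 4-chloro-3-fluorophenyl: chloro in place of fluoro on an aromatic carbon. The nitro step lies elsewhere in the molecule and does not apply here, since compound 4 keeps the nitro group. The closest guide is the halogen change on the aryl group, a 1.5-fold higher number from compound 1 to compound 3 (0.18 log units; within the scatter). Within the data shown here, no chloro compound has been measured, so this guide is a single, indirect one. On the basis of that small step, no change beyond the scatter is expected in this assay. The estimated step is a 1.2-fold lower number from compound 3 to compound 4 (0.09 log units; within the scatter). For compound 4 the expected value is 100000 nM, with an estimated range of 50000 nM to 200000 nM.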

Compound 4, half-maximal inhibitory concentration: 89200 nM
For compound 4 the middle estimate is 1.1-fold (0.05 log units) above the measured one; measured number inside the range.
By their numbers in this assay, from the lowest: compound 2; then compounds 1, 4 and 3 (each within the scatter of the next).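

Chloro in place of fluoro on an aromatic carbon, ortho to a fluoro group and para to a large group, gives in this assay a 1.4-fold lower number from compound 3 to compound 4 (0.14 log units; within the scatter), so the first change confined to this one halogen leaves the number within the scatter, with the nitro group kept. 4-Chloro-3-fluorophenyl in place of 4-bromophenyl gives a 1.1-fold higher number from compound 1 to compound 4 (0.05 log units; within the scatter), so compounds 1, 3 and 4 are not separated by their aryl ketone halogen patterns, whereas the nitro change remains the only step beyond the scatter, at an 8.7-fold higher number from compound 2 to compound 3 (0.94 log units; beyond the scatter). No supporting measurement is available to explain why this halogen exchange leaves the number within the scatter.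

On these data alone, it remains open whether chloro in place of fluoro would also stay within the scatter alongside trifluoromethyl, as carried by compound 2 at 14000 nM, rather than nitro. As far as these compounds go, it also remains open whether a methoxy group, a nitrile or an amine on this aromatic carbon, or a longer chain on the carbonyl, would move the number beyond the scatter in this assay.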